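From methyl to trifluoromethyl on compound 3

The source may report more compounds than this note shows. Statements on the series, on what has been measured and on what is new or still open speak of the compounds shown alone.

Measured so far in a functional assay on A549 cells (Homo sapiens) for cytotoxicity, read by MTT assay, with a stated time of 48 h (a lower number here means a stronger inhibitor, a higher number a weaker inhibitor), are three compounds:

Compound 1 (`COc1cc(/C=C/c2ccccc2)c(-c2ccccc2)c(OC)c1OC`): 79000 nM
Compound 2 (`C=C(c1ccccc1)c1cc(OC)c(OC)c(OC)c1-c1ccccc1`): 17000 nM
Compound 3 (`C=C(c1ccc(C)cc1)c1cc(OC)c(OC)c(OC)c1-c1ccccc1`): 35000 nM

Compound 3 holds the middle place among these three numbers. It lies on one side of compound 1, with a 2.3-fold lower number from compound 1 to compound 3 (0.35 log units; beyond the scatter) separating them, and on the other side of compound 2, with a 2.1-fold higher number from compound 2 to compound 3 (0.31 log units; beyond the scatter) as the gap.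

The next molecule is compound 4 (`C=C(c1ccc(C(F)(F)F)cc1)c1cc(OC)c(OC)c(OC)c1-c1ccccc1`), not yet measured. The change (trifluoromethyl in place of methyl on an aromatic carbon) is trifluoromethyl in place of methyl on an aromatic carbon, para to a large group.

Among the compounds with values here, only one measured step touches this same place: the one already seen between compound 2 and compound 3, where methyl replaced hydrogen. It was modest, only just beyond the usual scatter. The other steps, such as a 4.6-fold lower number from compound 1 to compound 2 (0.67 log units; beyond the scatter) in size, change a different part of the molecule and bear little on this question. Within the data shown here, no compound yet carries trifluoromethyl, so the data give no firm direction.

A small step is therefore expected in this assay, estimated as a 1.2-fold lower number from compound 3 to compound 4 (0.07 log units; within the scatter) and not clearly beyond the scatter. For compound 4 the expected value is 30000 nM (estimated range 12000 nM to 75000 nM).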

Compound 4, half-maximal inhibitory concentration: 48000 nM
The estimate for compound 4 lay 1.6-fold (0.20 log units) below the measured number; measured number inside the range.
By their numbers in this assay, from the lowest: compound 2; then compounds 3, 4 and 1 (each within the scatter of the next, the first and the last beyond it).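

In this assay, going from the 4-methylphenyl to the 4-(trifluoromethyl)phenyl group gives a 1.4-fold higher number from compound 3 to compound 4 (0.14 log units; within the scatter), so at this position the two groups cannot be told apart, even though trifluoromethyl brings three fluorine atoms that methyl lacks. Measured against plain hydrogen at the same place, trifluoromethyl gives a 2.8-fold higher number from compound 2 to compound 4 (0.45 log units; beyond the scatter), which makes it the second group here, after methyl, to leave the number higher than hydrogen does, and among these three compounds hydrogen therefore remains the best of the groups tried at this position, with no compound going against that. Nothing available on these compounds explains this picture, so it stands as a plain observation of cell-killing numbers and no more.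

The compounds shown leave open whether any group at this position can bring the number lower than hydrogen does, since only hydrogen, methyl and trifluoromethyl appear there and a methoxy group, an amine or a carboxylic acid might behave quite differently. They also leave open whether the same small differences would hold on the 2-phenylethenyl compound 1, which carries no such group on that ring.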